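A fluoro to methoxy swap on compound 2

The source may report more compounds than this note shows. Statements on the series, on what has been measured and on what is new or still open speak of the compounds shown alone.

Of the compounds shown here, three have so far been measured in a physicochemical assay for lipophilicity (a higher number here means a more lipophilic compound, a lower number a more polar compound), and no two of them differ in one place only. Compound 2 `COc1c(OC)c(OC(C)=O)c2cc(F)ccc2c1OC(C)=O` gives 2.75 and holds the lowest of the three numbers. Compound 1 `CCC(=O)Oc1c(OC)c(OC)c(OC(=O)CC)c2ccccc12` stands nearest at 3.44 and compound 3 `COc1c(OC)c(OC(=O)C(C)(C)C)c2c(OC)cccc2c1OC(=O)C(C)(C)C` stands furthest at 5.6 on the same scale, and both gaps from compound 2 lie beyond the scatter.

Compound 4 `COc1ccc2c(OC(C)=O)c(OC)c(OC)c(OC(C)=O)c2c1` has not yet been measured. The change methoxy in place of fluoro on an aromatic carbon puts methoxy in place of fluoro on an aromatic carbon and leaves the rest of compound 2 untouched. The measured compounds offer no direct reading of this swap, so the expectation rests on the size of the structural change alone. In this assay no step beyond the scatter is expected, with at most a slight fall. The step of a number 0.10 log units lower from compound 2 to compound 4 (within the scatter) is estimated to be small. The expectation therefore stays close to compound 2 at 2.75 and does not reach toward the higher numbers of the other two compounds. For compound 4 the expected value is 2.65 with an estimated range from 2.3 to 3 once the measurement is made.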

Compound 4, partition coefficient: 2.39
For compound 4 the middle estimate is 0.26 log units above the measured one, within the range that was stated.
By their numbers in this assay, from the lowest: compound 4; then compound 2; then compound 1; then compound 3.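

Read in this assay, the replacement of fluoro by methoxy gives a number 0.36 log units lower from compound 2 to compound 4 (beyond the scatter) and so provides the first direct reading of a change at this position, on an aromatic carbon meta to a fused ring and para to a fused ring. The step is modest, but it shows that this position is not silent in this assay, and that a swap bringing in 2 heavy atoms and 1 hydrogen-bond acceptor for 1 heavy atom and none goes with a lower number here, not a higher one. Nothing at hand bears on why the step runs in this direction.

The compounds shown leave open how other groups would read at this same carbon, such as an amine, a carboxylic acid or a longer ether chain like butoxy, and so whether the number follows group size at all. They also leave open whether the same swap would give a step of like size with the other ester groups carried by compound 1 and compound 3.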